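Swapping the Amino and Fluoro Positions on the Sulfonyl Aryl Group

The source may report more compounds than this note shows. Statements on the series, on what has been measured and on what is new or still open speak of the compounds shown alone.

Values measured in a functional assay on DU-145 cells (Homo sapiens) for inhibition, read by trypan blue exclusion, with a stated time of 72 h; on this read-out lower numbers stand for stronger inhibition and higher numbers for weaker inhibition:
compound 1 `Cn1c(=O)c(S(=O)(=O)c2ccc(F)cc2[N+](=O)[O-])cc2cnc(Nc3ccc4[nH]ccc4c3)nc21` gives 1500 nM
compound 2 `Cn1c(=O)c(S(=O)(=O)Nc2ccc(F)cc2F)cc2cnc(Nc3ccc4[nH]ccc4c3)nc21` gives 5000 nM
compound 3 `Cn1c(=O)c(S(=O)(=O)c2ccc(N)cc2F)cc2cnc(Nc3ccc4[nH]ccc4c3)nc21` gives 8000 nM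

Compound 3, at 8000 nM, cannot be told apart from compound 2 within the scatter (a 1.6-fold higher number from compound 2 to compound 3 (0.20 log units; within the scatter)), but it stands clear of compound 1 (a 5.3-fold higher number from compound 1 to compound 3 (0.73 log units; beyond the scatter)). The next compound, compound 4 `Cn1c(=O)c(S(=O)(=O)c2ccc(F)cc2N)cc2cnc(Nc3ccc4[nH]ccc4c3)nc21`, carries 2-amino-4-fluorophenyl in place of 4-amino-2-fluorophenyl on a sulfonyl sulfur. For the measured compounds named here, no measured step makes this exchange alone, so its size can only be inferred. The other changes at this place were modest at most, as the steps above and a 3.3-fold higher number from compound 1 to compound 2 (0.52 log units; beyond the scatter) show. In this assay, a small shift is therefore expected, with no firm direction beyond the scatter. The entering group shares the 4-fluoro of the group in compound 1, at 1500 nM, which leans the expectation slightly towards a lower number. The expected step is a 1.6-fold lower number from compound 3 to compound 4 (0.20 log units; within the scatter). For compound 4 the estimate is 5000 nM, with an expected range of 1500 nM to 15000 nM.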

Compound 4, half-maximal inhibitory concentration: 3000 nM
Compound 4: the middle estimate sits 1.7-fold (0.22 log units) above what was measured; measured number inside the range.
By their numbers in this assay, from the lowest: compounds 1, 4, 2 and 3 (each within the scatter of the next, the first and the last beyond it).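

In this assay, moving from 4-amino-2-fluorophenyl to 2-amino-4-fluorophenyl on the sulfonyl sulfur gave a change beyond the scatter (a 2.7-fold lower number from compound 3 to compound 4 (0.43 log units; beyond the scatter)), so the arrangement of the same two substituents on this aryl group matters here, not just which atoms are present. By contrast, amino in place of nitro on an aromatic carbon stayed within the scatter (a 2.0-fold higher number from compound 1 to compound 4 (0.30 log units; within the scatter)), as did 2-amino-4-fluorophenyl in place of (2,4-difluorophenyl)amino (a 1.7-fold lower number from compound 2 to compound 4 (0.22 log units; within the scatter)). Nothing available explains why the rearrangement shifts the number.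

Going by these compounds, it remains open whether a hydroxyl or methoxy group in place of the amino, or a chlorine in place of the fluorine, would keep or lose this dependence on arrangement. On these data alone, it is also open whether the amino group of compound 4 would give a similar number on a phenyl ring carrying no fluorine.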